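A Methyl on the Linker Chain: Expected Cytotoxicity

The compounds below may be only part of what the source reports. "The series", "measured", "known", "first", "only" and "open" are said of these compounds alone.

Of the compounds shown here, two sharing one core have been tested in an ADME assay on NIH3T3 cells (Homo sapiens) for cytotoxicity against NIH3T3 (Mus musculus), read by MTT assay, with a stated time of 72 h; a lower number here means a stronger inhibitor, a higher number a weaker inhibitor. Compound 1, `C#CCn1cc(C(=O)NCCCOC(=O)[C@H]2OC(C)(C)N(C(=O)OC(C)(C)C)[C@@H]2c2ccccc2)c(=O)c2ccc(Cl)nc21`, returns only a limit in this assay: the result for compound 1 is > 10000 nM. For the measured compounds named here, compound 2, `C#CCn1cc(C(=O)NCCCOC(=O)[C@H](C)NC(=O)OC(C)(C)C)c(=O)c2ccc(Cl)nc21`, gives the single measured number in this assay, 9200 nM. Compound 2 therefore stands as the only quantified point; the other result is the limit of > 10000 nM in this assay, at which 1 of the 2 values shown sits. Compound 3, `C#CCn1cc(C(=O)N[C@@H](C)CCOC(=O)[C@H](C)NC(=O)OC(C)(C)C)c(=O)c2ccc(Cl)nc21`, differs from compound 2 by methyl in place of hydrogen on a saturated chain carbon bound to an amide-type nitrogen and a saturated chain carbon. Going by the values given here, no step between two measured compounds is available, so this change has no direct precedent here. Because compound 2 already sits at 9200 nM, a weak reading, the step is expected to stay within the usual scatter, with no clear direction. Compound 3 is therefore expected to give about 9000 nM, between 4000 nM and 20000 nM, which corresponds to an expected step of a 1.0-fold lower number from compound 2 to compound 3 (0.01 log units; within the scatter).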

Compound 3, half-maximal inhibitory concentration: > 10000 nM
Compound 3: only a limit was reported; the forecaster's own chance of this, stated with the estimate: 50%; at least 1.1-fold (0.04 log units) between middle value and limit.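

For the compounds shown here, this is the first look at this position: methyl in place of hydrogen on a saturated chain carbon bound to an amide-type nitrogen and a saturated chain carbon gives an at least 1.0-fold higher number from compound 2 to compound 3 (0.03 log units; that floor lies within the scatter) in this assay. The result for compound 3 is a limit, so this step has a floor but no known size. The change thus brings no sign of stronger cytotoxicity at this position, and most of the compounds shown now share one limit: the limit of > 10000 nM in this assay, at which 2 of the 3 values shown sit.

Going by these compounds, whether an ethyl group or an amine on this same carbon would give a measurable number in this assay remains open. On these data alone, the true size of the methyl step also remains open, as does whether methyl would have any effect on a compound with a much lower starting number.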